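Replacing diethylamino with diisopropylamino in compound 3

The compounds below may be only part of what the source reports. "The series", "measured", "known", "first", "only" and "open" are said of these compounds alone.

- Compound 1 `CC(C)=CCC[C@]1(C)/C=C/[C@@H](OC(=O)C=C(C)C)[C@](C)(O)/C=C/C(=O)/C(C(=O)O)=C\C1`: 16100 nM
- Compound 2 `CC(C)=CCC[C@]1(C)/C=C/[C@@H](OC(=O)C=C(C)C)[C@](C)(O)/C=C/C(=O)/C(CN(C)C)=C\C1`: 690 nM
- Compound 3 `CCN(CC)C/C1=C/C[C@](C)(CCC=C(C)C)/C=C/[C@@H](OC(=O)C=C(C)C)[C@](C)(O)/C=C/C1=O`: 130 nM

All three values come from a functional assay on MCF7 cells (Homo sapiens) for antiproliferative activity, read by MTT assay, with a stated time of 48 h; on this read-out lower numbers stand for stronger inhibition and higher numbers for weaker inhibition. Compound 3 has the lowest number of the three, 130 nM, and its nearest neighbour is compound 2. Compound 4 `CC(C)=CCC[C@]1(C)/C=C/[C@@H](OC(=O)C=C(C)C)[C@](C)(O)/C=C/C(=O)/C(CN(C(C)C)C(C)C)=C\C1` has not yet been measured. It keeps the shared core and differs from compound 3 in one place: diisopropylamino in place of diethylamino on a saturated chain carbon bound to a double-bonded ring carbon. In words, diisopropylamino stands in place of diethylamino on a saturated chain carbon bound to a double-bonded ring carbon.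

The closest measured precedent is a 5.3-fold lower number from compound 2 to compound 3 (0.72 log units; beyond the scatter), which has diethylamino in place of dimethylamino at that same place. The larger steps, a 23-fold lower number from compound 1 to compound 2 (1.37 log units; beyond the scatter) and a 120-fold lower number from compound 1 to compound 3 (2.09 log units; beyond the scatter), replace carboxy and say little about exchanging one amino group for another. A single modest step does not establish a trend, so only a small further fall is expected in this assay, quite possibly none beyond the scatter, and a rise cannot be excluded. The expected step is a 1.3-fold lower number from compound 3 to compound 4 (0.11 log units; within the scatter). The estimate for compound 4 is 100 nM, with an expected range of 30 nM to 350 nM.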

Compound 4, half-maximal inhibitory concentration: 780 nM
Compound 4: the middle estimate sits 7.8-fold (0.89 log units) below what was measured, and the stated range ends below it.
By their numbers in this assay, from the lowest: compound 3; then compounds 2 and 4 (each within the scatter of the next); then compound 1.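

In this assay the amine on this saturated chain carbon bound to a double-bonded ring carbon does not follow a simple line: the gain seen in a 5.3-fold lower number from compound 2 to compound 3 (0.72 log units; beyond the scatter) with diethylamino in place of dimethylamino does not continue, and diisopropylamino gives a 6.0-fold higher number from compound 3 to compound 4 (0.78 log units; beyond the scatter) instead. Within the data shown here, the dimethylamino and diisopropylamino compounds cannot be told apart, with a 1.1-fold higher number from compound 2 to compound 4 (0.05 log units; within the scatter) and so no real difference between them, which leaves diethylamino as the one group of these three that stands clear of the other two and shows that more carbon on the amine does not by itself lower the number. Even so, the amine series keeps its large separation from the carboxy compound, as a 21-fold lower number from compound 1 to compound 4 (1.31 log units; beyond the scatter) shows for diisopropylamino, so the choice of amino group tunes a gain that all three amines share.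

No other data shown here bear on why the numbers fall this way. The compounds shown leave open where a ring amine such as piperidine or morpholine, or a straight-chain dipropylamino group, would fall, and so whether diethylamino marks a true optimum at this place or just the best of three.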